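From bromo to trifluoromethyl on the aromatic ring

The compounds below may be only part of what the source reports. "The series", "measured", "known", "first", "only" and "open" are said of these compounds alone.

Compound 1 `C#CCNC1CCc2c(SCc3cccc(F)c3)cccc21`: 1480 nM in an assay on isolated protein for inhibition of Amine oxidase [flavin-containing] B (Homo sapiens); a higher number here means a weaker inhibitor, a lower number a stronger inhibitor
Compound 2 `C#CCNC1CCc2c(SCc3cccc(C)c3)cccc21`: > 100000 nM, a limit of the assay
Compound 3 `C#CCNC1CCc2c(SCc3cccc(Br)c3)cccc21`: > 100000 nM, a limit of the assay

Compound 3 stands at the weak end of this small set, its value known only as a limit, the same one at which compound 2 sits (the limit of > 100000 nM in this assay, at which 2 of the 3 values shown sit). Compound 4 `C#CCNC1CCc2c(SCc3cccc(C(F)(F)F)c3)cccc21` differs from compound 3 by trifluoromethyl in place of bromo on an aromatic carbon. The measured steps bearing on this position are an at least 67-fold higher number from compound 1 to compound 3 (1.82 log units; beyond the scatter) and an at least 67-fold higher number from compound 1 to compound 2 (1.82 log units; beyond the scatter), while a step that the two limits leave unreadable from compound 2 to compound 3. Since both methyl and bromo at this carbon gave only the limit, a trifluoromethyl group there is expected to give a number at or near that limit as well: compound 4 is estimated at 80000 nM, between 10000 nM and 300000 nM, which means an at least 1.2-fold lower number from compound 3 to compound 4 (0.09 log units; that floor lies within the scatter) in this assay.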

Compound 4, half-maximal inhibitory concentration: 4.7 nM
Beside the measured number, compound 4's estimate is 17000-fold (4.23 log units) above it; the measured number lies below the stated range.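

Among the compounds shown here, at this aromatic carbon, the earlier compounds gave no sign that any group could do better than fluoro, yet trifluoromethyl gives an at least 21000-fold lower number from compound 3 to compound 4 (4.32 log units; beyond the scatter) and an at least 21000-fold lower number from compound 2 to compound 4 (4.32 log units; beyond the scatter). It also gives a 310-fold lower number from compound 1 to compound 4 (2.50 log units; beyond the scatter), so a single change here spans nearly the whole range seen in this assay. The first two steps start from values that are limits of the assay: the limit of > 100000 nM in this assay, at which 2 of the 4 values shown sit.

As far as these compounds go, whether a methoxy, a nitrile or an amine at this carbon would behave like trifluoromethyl or like bromo stays open. So does whether trifluoromethyl would give a similar number on another carbon of that ring.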